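Chloro in place of trifluoromethyl: expecting compound 3

This account rests on a few compounds, and the source may have more. Where it says the series, first, only, none or still open, it means among the compounds named here.

Compound 1 `COc1cc2cc(Oc3ccc(NC(=O)Nc4ccc(C(F)(F)F)cc4)cc3)c(C)nc2cc1OC` gives 64.4% in a functional assay on KM12 cells (Homo sapiens) for inhibition, read by sulforhodamine B assay, with a stated time of 48 h, tested at 10 uM; a higher number here means a weaker effect of the compound at the concentration tested, a lower number a stronger effect.
Compound 2 `COc1cc2cc(Oc3ccc(NC(=O)Nc4ccc(Cl)c(C(F)(F)F)c4)cc3)c(C)nc2cc1OC` gives -16.4% in this assay.

Compound 2 stands lowest of these two numbers; its nearest neighbour is compound 1, and the step of a number 80.8 percentage points lower from compound 1 to compound 2 (beyond the scatter) is large. Compound 3 `COc1cc2cc(Oc3ccc(NC(=O)Nc4ccc(Cl)c(Cl)c4)cc3)c(C)nc2cc1OC` differs from compound 2 by chloro in place of trifluoromethyl on an aromatic carbon. Among the measured compounds shown here, the one measured step, a number 80.8 percentage points lower from compound 1 to compound 2 (beyond the scatter), concerns a different exchange on that ring, so it gives no direct guide to the present change. Without a bearing step, the expectation is a step of a number 16.4 percentage points higher from compound 2 to compound 3 (beyond the scatter) within the scatter, in no firm direction. Compound 3 is therefore estimated at 0%, within -40% to 45% in this assay.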

Compound 3, a percentage reported as activity, at one concentration (the size of the read-out at that concentration, not a potency): 13.9%
Beside the measured number, compound 3's estimate is 13.9 percentage points below it, and the stated range covers the measured number.
By their numbers in this assay, from the lowest: compound 2; then compound 3; then compound 1.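

On the aromatic carbon that carries trifluoromethyl in compound 2, chloro is not an equal exchange: this assay records a number 30.3 percentage points higher from compound 2 to compound 3 (beyond the scatter) for this change, so the read-out depends on which of these two groups sits there. The 3,4-dichlorophenyl group still keeps much of the gain over 4-(trifluoromethyl)phenyl, with a number 50.5 percentage points lower from compound 1 to compound 3 (beyond the scatter) in this assay for that exchange. No measurement shown accounts for these differences.

On these data alone, it remains open whether a nitrile, a methyl group or an amine on this same carbon would give a number closer to compound 2 or to compound 3.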